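This account rests on a few compounds, and the source may have more. Where it says the series, first, only, none or still open, it means among the compounds named here.

Working notes on the series in an ADME assay on NHDF cells (Homo sapiens) for cytotoxicity, read by MTT assay, with a stated time of 72 h; on this read-out higher numbers stand for weaker inhibition and lower numbers for stronger inhibition. Compound 1 `COc1ccc(/C=C2\CCC/C(=C\c3cccc(OC)c3OC)C2=O)cc1OC` gives 14900 nM. Compound 2 `COc1cc(/C=C2\CCC/C(=C\c3cccc(OC)c3OC)C2=O)ccc1O`, which carries hydrogen in place of methyl on an oxygen on an aromatic ring, gives 14300 nM; the step of a 1.0-fold lower number from compound 1 to compound 2 (0.02 log units; within the scatter) is within the scatter. Compound 3 `COc1cc(/C=C2\CCC/C(=C\c3ccc(OC)c(OC)c3)C2=O)ccc1O` gives 13700 nM; its values and those of compound 1 and compound 2 all lie within the scatter of one another, and the difference between the cores of compound 1 and compound 3 is not broken down here.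

Compound 4 `COc1ccc(/C=C2\CCC/C(=C\c3ccc(O)c(O)c3)C2=O)cc1OC` is not yet measured. It carries hydrogen in place of methyl on an oxygen on an aromatic ring, the same change as from compound 1 to compound 2, at a place described in the same words; cut one bond further out it reads 4-hydroxy-3-methoxyphenyl to 3,4-dihydroxyphenyl. Because the earlier step of a 1.0-fold lower number from compound 1 to compound 2 (0.02 log units; within the scatter) stayed within the scatter, the step from compound 3 to compound 4 is expected to be about as small, a 1.0-fold lower number from compound 3 to compound 4 (0.01 log units; within the scatter). For compound 4 the estimated value is 13500 nM, with an expected range from 8000 nM to 25000 nM.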

Compound 4, half-maximal inhibitory concentration: 25200 nM
The estimate for compound 4 lay 1.9-fold (0.27 log units) below the measured number; measured number above the stated range.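

In this assay the step for hydrogen in place of methyl on an oxygen on an aromatic ring is a 1.8-fold higher number from compound 3 to compound 4 (0.26 log units; within the scatter), and it lies within the scatter. Set beside the earlier step on the other core, it does not differ by more than two such steps can scatter: the same change on two cores in this assay, a 1.0-fold lower number (0.02 log units; within the scatter) from compound 1 to compound 2 and a 1.8-fold higher number (0.26 log units; within the scatter) from compound 3 to compound 4, 1.9-fold (0.28 log units) apart, within the scatter of two such steps. This shows no sign that the change behaves differently on these two cores, but it does not show that the change is without effect, and two steps cannot establish that it carries over to other cores.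

The compounds shown leave open what a group other than methoxy or hydroxy, such as an amine, a carboxylic acid or a longer alkoxy chain, would do on these aromatic rings. They also leave open whether any such group would give a step beyond the scatter.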